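A Pyrazole in Place of Dimethylaminophenyl: Expected Solubility

The compounds below may be only part of what the source reports. "The series", "measured", "known", "first", "only" and "open" are said of these compounds alone.

Compound 3 `Cc1cc(NCc2ccccn2)n2ncc(-c3ccc(N(C)C)cc3)c2n1` was examined in a physicochemical assay for solubility, read by HPLC, using the shake flask method, measured as kinetic solubility, with a stated time of 2 h, at pH 7.4; a lower number here means a less soluble compound, a higher number a more soluble compound. In this assay compound 3 gives only a limit, < 5000 nM. Compound 1 `Cc1cc(NCc2ncc[nH]2)n2nc(C)c(-c3ccccc3)c2n1` likewise gives only a limit in this assay, < 5000 nM. Compound 2 `Cc1cc(NCc2nccs2)n2nc(C)c(-c3ccccc3)c2n1` gives 108000 nM in this assay. Within the data shown here, the single measured step, an at least 21-fold higher number from compound 1 to compound 2 (1.33 log units; beyond the scatter), concerns a change elsewhere on the shared core, so it does not directly inform the present step; what compounds 1 and 3 share is the limit of < 5000 nM in this assay, at which 2 of the 3 values shown sit. Compound 4 `Cc1cc(NCc2ccccn2)n2ncc(-c3ccn(C)n3)c2n1` differs from compound 3 by 1-methyl-1H-pyrazol-3-yl in place of 4-(dimethylamino)phenyl on an aromatic carbon. Among the measured compounds shown here, with no measured step of this kind available, the direction is open, but a moderate rise is expected, an at least 3.0-fold higher number from compound 3 to compound 4 (0.47 log units; beyond the scatter), and a further limit remains possible. Compound 4 is estimated at 15000 nM, between 3000 nM and 80000 nM.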

Compound 4, solubility: 188000 nM
Estimate against measurement, compound 4: 13-fold (1.10 log units) below; the measured number lies above the stated range.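

In this assay, this aromatic carbon of the five-membered ring proves highly responsive to its substituent: 1-methyl-1H-pyrazol-3-yl in place of 4-(dimethylamino)phenyl gives an at least 37-fold higher number from compound 3 to compound 4 (1.57 log units; beyond the scatter). Among these compounds, the earlier step concerned a change elsewhere on the shared core, so this is the first reading at this place. Compound 3 gives a limit, not a number, and so does compound 1: the limit of < 5000 nM in this assay, at which 2 of the 4 values shown sit.

Whether the dimethylamino group or the whole phenyl ring accounts for the step remains open. So does how a 4-methoxyphenyl or a 1-methyl-1H-pyrazol-4-yl would read at this place.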